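Moving one fluorine on the phenyl ring

The compounds below may be only part of what the source reports. "The series", "measured", "known", "first", "only" and "open" are said of these compounds alone.

Compound 1 `Oc1nc(-c2ccc(F)cc2)nc2ccccc12`: > 20 ug/mL, a limit and not a number
Compound 2 `COc1cc2nc(-c3ccccc3F)nc(O)c2cc1OC`: 13.1 ug/mL

For the measured compounds named here, in a functional assay on MCF7 cells (Breast, Homo sapiens) (on this read-out lower numbers stand for an effect already at smaller amounts and higher numbers for an effect only at larger amounts of compound), compound 2 gives 13.1 ug/mL, the only actual number among the measured compounds. Compound 1 stands at the limit of > 20 ug/mL in this assay, at which 1 of the 2 values shown sits. Going by the values given here, a limit cannot be set against a number as a step, so the two compounds give no measured step to build on.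

Compound 3 `COc1cc2nc(-c3cccc(F)c3)nc(O)c2cc1OC` has not yet been measured. It differs from compound 2 in one place, on an aromatic carbon between two ring nitrogen atoms, where 3-fluorophenyl stands in place of 2-fluorophenyl: 3-fluorophenyl in place of 2-fluorophenyl on an aromatic carbon. Among the compounds with values here, the two compounds have the same atoms, joined differently, and no measured pair shows what such a change does.

With so little to go on, no step beyond the usual scatter is expected in this assay, and neither direction is favoured. The estimate therefore rests on compound 2 at 13.1 ug/mL. The expected change is a 1.1-fold higher number from compound 2 to compound 3 (0.03 log units; within the scatter). For compound 3 the estimated value is 14 ug/mL, with an expected range of 6.5 ug/mL to 20 ug/mL.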

Compound 3, concentration for half-maximal effect: "not active" (no number reported)
Nothing numeric was reported for compound 3; no gap can be computed for the estimate.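

For the compounds shown here, compound 3 was reported only as "not active", with no number, so no step from compound 2 to compound 3 can be read. The compounds shown leave open how large a change, if any, 3-fluorophenyl in place of 2-fluorophenyl brings to the value of compound 2, which stands at 13.1 ug/mL.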